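Compound 3 and a new aromatic group

The compounds below may be only part of what the source reports. "The series", "measured", "known", "first", "only" and "open" are said of these compounds alone.

Measured so far in an assay on isolated protein for inhibition of serine protease 1 (Homo sapiens), tested at 100 uM; on this read-out higher numbers stand for more inhibition at the one concentration tested (going by the name of the read-out) and lower numbers for less inhibition:
compound 1 `CC1CCCC(C)N1CCCCCN1C(=O)C(c2ccc(Cl)c(Cl)c2)Oc2ccccc21` gives 14%;
compound 2 `CC1CCCC(C)N1CCCCCN1C(=O)C(c2cccc(C(=N)NO)c2)Oc2ccccc21` gives 21%;
compound 3 `CC1CCCC(C)N1CCCCCN1C(=O)C(c2ccc(Cl)cc2)Oc2ccccc21` gives 46%.

Compound 3 stands highest of these three numbers. Both steps toward it lie beyond the scatter: a number 32 percentage points higher from compound 1 to compound 3 (beyond the scatter), and a number 25 percentage points higher from compound 2 to compound 3 (beyond the scatter).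

Compound 4 `C/N=C(/N)c1cccc(C2Oc3ccccc3N(CCCCCN3C(C)CCCC3C)C2=O)c1` has not been measured in this assay. It differs from compound 3 in one place: a group of 10 heavy atoms (8 carbon, 2 nitrogen; one six-membered aromatic ring of carbon only) in place of a group of 7 heavy atoms (6 carbon, 1 chlorine; one six-membered aromatic ring of carbon only), on a saturated ring carbon. For the measured compounds named here, the measured step that bears on this is the one between compound 2 and compound 3, where a group of 10 heavy atoms on the same saturated ring carbon was exchanged for the 4-chlorophenyl, with the result a number 25 percentage points higher from compound 2 to compound 3 (beyond the scatter). Compound 4 goes the other way, from the 4-chlorophenyl to a group of 10 heavy atoms, so a step downward of roughly that size is expected: a number 24 percentage points lower from compound 3 to compound 4 (beyond the scatter). For compound 4 the expected value in this assay is 22%, with a range from 5% to 42%.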

Compound 4, a percentage reported as inhibition, at one concentration (the size of the read-out at that concentration, not a potency): 32%
For compound 4 the middle estimate is 10 percentage points below the measured one; the measured number falls inside the stated range.
By their numbers in this assay, from the lowest: compounds 1 and 2 (each within the scatter of the next); then compound 4; then compound 3.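

In this assay, exchanging only the small side group on an aromatic carbon already moves the result (a number 11 percentage points higher from compound 2 to compound 4 (beyond the scatter)), so this position responds to the side group and not just to the presence of an aromatic ring. The new aromatic group ranks between two chlorinated rings on the saturated ring carbon: it falls short of the 4-chlorophenyl (a number 14 percentage points lower from compound 3 to compound 4 (beyond the scatter)) but exceeds the dichlorinated ring of compound 1 (a number 18 percentage points higher from compound 1 to compound 4 (beyond the scatter)). No measurement here explains either shift.

The compounds shown leave open how an aminomethyl group or a carboxylic acid on that same aromatic carbon would read. As far as these compounds go, it also remains open whether the gap to compound 3 comes from the side group itself or from where it sits on the ring.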